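Permeability across a Caco-2 layer: compound 1 to compound 4

A few compounds are considered here, and "the series" means these few. Any claim that something is new, unique, unknown or untested is made for them only; others in the source may bear on it.

Measured compounds:
- compound 1, `Cn1cncc1CN1CC(N(CC2CCN(C(=O)CC(C)(C)C)CC2)S(=O)(=O)c2ccccn2)Cc2cc(C#N)ccc21`: 0.5 10^-6 cm/s
- compound 2, `Cn1cncc1CN1CC(N(Cc2cccc(-n3cccc3)c2)S(=O)(=O)c2ccccn2)Cc2cc(C#N)ccc21`: 2.3 10^-6 cm/s
- compound 3, `Cn1cnc(S(=O)(=O)N(Cc2cccc(-n3cccc3)c2)C2Cc3cc(C#N)ccc3N(Cc3cncn3C)C2)c1`: 0.2 10^-6 cm/s

In an ADME assay on Caco-2 cells (Homo sapiens) for permeability, in the apical to basolateral direction (a lower number here means that the compound crosses the layer more slowly, a higher number that the compound crosses the layer faster), compound 1 stands second highest of the three numbers. Compound 3 is nearest to it, and compound 2 is furthest, giving the highest number of the three. Going by the values given here, the one step between two compounds that differ in a single place is a 12-fold lower number from compound 2 to compound 3 (1.06 log units; beyond the scatter); it concerns a group on a sulfonyl sulfur and does not touch the part of the molecule that changes here.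

Compound 4, `Cn1cncc1CN1CC(N(CC2CCN(C(=O)c3ccco3)CC2)S(=O)(=O)c2ccccn2)Cc2cc(C#N)ccc21`, differs from compound 1 as follows: furan-2-yl in place of neopentyl on a carbonyl carbon. Among the compounds with values here, no measured step bears on this change, so there is nothing in the data to argue for a shift in either direction beyond the scatter of this assay. The expected step is therefore no change at the digits printed from compound 1 to compound 4 (within the scatter), a number close to that of compound 1 with a range wide enough to cover a modest movement either way. Compound 4 is estimated at 0.5 10^-6 cm/s, between 0.2 10^-6 cm/s and 1.3 10^-6 cm/s.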

Compound 4, apparent permeability: 0.5 10^-6 cm/s
Beside the measured number, compound 4's estimate shows no gap at the digits printed; the range from low to high includes it.
By their numbers in this assay, from the lowest: compound 3; then compounds 1 and 4 (each within the scatter of the next); then compound 2.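

In this assay, furan-2-yl in place of neopentyl on the carbonyl carbon gives no change at the digits printed from compound 1 to compound 4 (within the scatter), the only step shown at this position, since the earlier step concerned the group on the sulfonyl sulfur. At this carbonyl carbon, this read-out therefore does not separate a group with no ring from one with a five-membered aromatic ring, although the two have the same count of heavy atoms and furan-2-yl adds a hydrogen-bond acceptor. Nothing available explains why the two groups give this result.

The compounds shown leave open whether a different kind of group on this carbonyl carbon, such as a chain ending in an amine or a carboxylic acid, would move the number beyond the scatter. They also leave open whether this exchange would read the same with 1-methyl-1H-imidazol-4-yl on the sulfonyl sulfur.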